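From bromo to methyl at the assay limit

The source may report more compounds than this note shows. Statements on the series, on what has been measured and on what is new or still open speak of the compounds shown alone.

Measured so far in a functional assay on A549 cells (Homo sapiens) for cytotoxicity, read by MTT assay, with a stated time of 72 h; on this read-out higher numbers stand for weaker inhibition and lower numbers for stronger inhibition:
- Compound 1 `CNC(=O)c1cc(Oc2ccc(NC(=O)c3cc(-c4ccc(C)cc4)ncn3)cc2)ccn1` gives > 100000 nM, a limit
- Compound 2 `CNC(=O)c1cc(Oc2ccc(NC(=O)c3cc(-c4ccc(C(F)(F)F)cc4)ncn3)cc2F)ccn1` gives > 100000 nM, a limit
- Compound 3 `CNC(=O)c1cc(Oc2ccc(NC(=O)c3cc(-c4ccc(Br)cc4)ncn3)cc2F)ccn1` gives > 100000 nM, a limit

Compound 3 has the reading > 100000 nM, which is a limit and not a number. It shares that reading with the other two compounds, as the limit of > 100000 nM in this assay, at which 3 of the 3 values shown sit, shows, so the numbers place it neither ahead of them nor behind them.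

The next compound, compound 4 `CNC(=O)c1cc(Oc2ccc(NC(=O)c3cc(-c4ccc(C)cc4)ncn3)cc2F)ccn1`, differs from it in one place: methyl in place of bromo on an aromatic carbon. This is methyl in place of bromo on an aromatic carbon, so 4-bromophenyl becomes 4-methylphenyl.

One measured step involves the same bromo group: a step that the two limits leave unreadable from compound 2 to compound 3. Both its ends are limits, so it offers no size to carry over. Compound 1 carries the 4-methylphenyl group as well, and its > 100000 nM is again a limit.

With no readable step to draw on and every reading at the limit, no real change is expected here. The expected step is a number no higher from compound 3 to compound 4 (the limit leaves the size open), and this is only an estimate. For compound 4 the estimated value is 100000 nM, with an expected range from 50000 nM to 200000 nM, and the assay will most likely report only a limit again.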

Compound 4, half-maximal inhibitory concentration: 13200 nM
The estimate for compound 4 lay 7.6-fold (0.88 log units) above the measured number; the measured number lies below the stated range.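

In this assay, for the compounds shown here, methyl in place of bromo on this aromatic carbon gives an at least 7.5-fold lower number from compound 3 to compound 4 (0.87 log units; beyond the scatter), and methyl in place of trifluoromethyl gives an at least 7.5-fold lower number from compound 2 to compound 4 (0.87 log units; beyond the scatter), so the group at this place matters, which the earlier compounds, all unreadable, could not show. Fluoro in place of hydrogen on an aromatic carbon gives an at least 7.5-fold lower number from compound 1 to compound 4 (0.87 log units; beyond the scatter), so methyl without the fluoro, as in compound 1, does not yield a readable number, and neither does the fluoro with bromo in compound 3 or with trifluoromethyl in compound 2. Among these compounds, only the pairing of methyl and fluoro in compound 4 gives a number, while the others give only a lower bound, so each step above states a minimum size: the limit of > 100000 nM in this assay, at which 3 of the 4 values shown sit.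

Going by these compounds, the step between trifluoromethyl and bromo cannot be read, so those two groups cannot be ranked against each other, and the full size of the steps to compound 4 stays open. The compounds shown also leave open whether an ethyl group, a methoxy group or an amine at this place would lower the number further, and whether chlorine could stand in for the fluoro.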